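Methyl for dimethylamino on the urea aryl ring

This account rests on a few compounds, and the source may have more. Where it says the series, first, only, none or still open, it means among the compounds named here.

Within the data shown here, compound 1 `CN(C)c1ccc(NC(=O)Nc2cccc(CNc3nccnc3Cl)c2)cc1` is the only compound with a number in a functional assay on T-24 cells (Homo sapiens) for antiproliferative activity, read by MTT assay, with a stated time of 48 h; on this read-out higher numbers stand for weaker inhibition and lower numbers for stronger inhibition: in it compound 1 gives 20200 nM. Its cyclohexyl analogue, compound 2 `O=C(Nc1cccc(CNc2nccnc2Cl)c1)NC1CCCCC1`, reaches only a limit of this assay; compound 2 gives > 40000 nM. Among the measured compounds shown here, the single measured step, an at least 1.9-fold higher number from compound 1 to compound 2 (0.29 log units; that floor lies within the scatter), rests on that limit (the limit of > 40000 nM in this assay, at which 1 of the 2 values shown sits). Compound 3 `Cc1ccc(NC(=O)Nc2cccc(CNc3nccnc3Cl)c2)cc1` differs from compound 1 by methyl in place of dimethylamino on an aromatic carbon. For the measured compounds named here, no measured step covers this exchange, so the step of a 1.2-fold higher number from compound 1 to compound 3 (0.09 log units; within the scatter) is expected to stay within the scatter. Compound 3 is estimated at 25000 nM, between 10000 nM and 60000 nM.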

Compound 3, half-maximal inhibitory concentration: 9820 nM
For compound 3 the middle estimate is 2.5-fold (0.41 log units) above the measured one; the whole stated range lies above it.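

Methyl in place of dimethylamino on this aromatic carbon gives the first step on the ring itself that lies beyond the scatter in this assay: a 2.1-fold lower number from compound 1 to compound 3 (0.31 log units; beyond the scatter). With the 4-methylphenyl group, the comparison with cyclohexyl also clears the scatter, an at least 4.0-fold lower number from compound 2 to compound 3 (0.60 log units; beyond the scatter). That step starts from compound 2, whose value is a limit and not a number: the limit of > 40000 nM in this assay, at which 1 of the 3 values shown sits.

The compounds shown leave open how a chlorine, a methoxy group or a carboxylic acid would read on this carbon. They also leave open whether the step reflects the arrival of methyl or the departure of dimethylamino.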